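This account rests on a few compounds, and the source may have more. Where it says the series, first, only, none or still open, it means among the compounds named here.

Measured compounds:
Compound 1 `O=C(NC1CCCCC1)c1cccn1-c1ccc2c(c1)B(O)OC2` in an ADME assay on L929 cells (Mus musculus) for cytotoxicity, read by resazurin assay, with a stated time of 72 h (on this read-out higher numbers stand for weaker inhibition and lower numbers for stronger inhibition), gives only a limit, > 10 ug/mL.
Compound 2 `O=C(c1ccn(-c2ccc3c(c2)B(O)OC3)c1)c1ccccc1Cl` in this assay likewise gives only a limit, > 10 ug/mL.

Among the compounds with values here, neither compound returns a number in this assay; both sit at the limit of > 10 ug/mL in this assay, at which 2 of the 2 values shown sit, so compound 2 cannot be placed above or below compound 1 on the values shown, and no step between measured compounds can be stated. Compound 3 `O=C(c1ccc(CO)cc1)c1ccn(-c2ccc3c(c2)B(O)OC3)c1` is not yet measured. It differs from compound 2 in one place: 4-(hydroxymethyl)phenyl in place of 2-chlorophenyl on a carbonyl carbon. With both measured values resting at the limit of > 10 ug/mL in this assay, at which 2 of the 2 values shown sit, the measured pair gives no size or direction of step to lean on; the expectation in this assay is a step of none beyond the scatter, with a reading that again ends at the limit as the likeliest outcome. The estimated step is a step that the limit leaves unreadable from compound 2 to compound 3. For compound 3 the estimate in this assay is 25 ug/mL, with a range of 8 ug/mL to 80 ug/mL.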

Compound 3, half-maximal inhibitory concentration: 9.31 ug/mL
Beside the measured number, compound 3's estimate is 2.7-fold (0.43 log units) above it; the measured number falls inside the stated range.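

In this assay, within the data shown here, the change to 4-(hydroxymethyl)phenyl in place of 2-chlorophenyl on a carbonyl carbon gives the first reading that is a number and not a limit. Going by these compounds, the step is an at least 1.0-fold lower number from compound 2 to compound 3 (0.03 log units; that floor lies within the scatter) and no more can be read from it, so this pair does not establish a real change at this position, and its true size stays unknown. The limit remains the most frequent reading among the compounds shown: the limit of > 10 ug/mL in this assay, at which 2 of the 3 values shown sit.

On these data alone, the true value of compound 2 remains unknown, so the size of the step stays open. Also open, as far as these compounds go, is how a carboxylic acid or an amine in place of the hydroxymethyl group would read in this assay on the same core.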